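The source may hold more compounds than are shown below. What is called first, only, known or untested is meant among the compounds shown, and "the series" means these compounds.

Measured compounds:
compound 1, `C[C@H]1CC[C@@H]2[C@@H](OC(=O)[C@]23CC(c2ccccc2)=NO3)[C@]2(C)C(=O)C=C[C@@]12O`, 1.41 in a physicochemical assay for lipophilicity; on this read-out lower numbers stand for lower lipophilicity and higher numbers for higher lipophilicity
compound 2, `C[C@H]1CC[C@@H]2[C@@H](OC(=O)[C@]23CC(c2ccccc2[N+](=O)[O-])=NO3)[C@]2(C)C(=O)C=C[C@@]12O`, 1.37 in this assay
compound 3, `C[C@H]1CC[C@@H]2[C@@H](OC(=O)[C@]23CC(c2ccc(Cl)cc2)N(c2ccccc2)O3)[C@]2(C)C(=O)C=C[C@@]12O`, 3.87 in this assay

Compound 3 stands highest of the three in this assay; the nearest is compound 1, the furthest compound 2, both well beyond the scatter from compound 3. Going by the values given here, the only step between compounds differing in one place is a number 0.04 log units lower from compound 1 to compound 2 (within the scatter), a nitro in place of hydrogen on an aromatic carbon, which stays within the scatter.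

Compound 4, `COc1ccc(C2C[C@@]3(ON2c2ccccc2)C(=O)O[C@@H]2[C@H]3CC[C@H](C)[C@]3(O)C=CC(=O)[C@@]23C)cc1Br`, is not yet measured. It differs from compound 3 in one place: 3-bromo-4-methoxyphenyl in place of 4-chlorophenyl on a saturated ring carbon. Among the compounds with values here, no measured pair changes a ring substituent of this kind, so the step from compound 1 to compound 2 bears on it only loosely, as a sign that a single change on an aromatic ring here moved nothing beyond the scatter. The expected step is therefore a number 0.18 log units higher from compound 3 to compound 4 (within the scatter), a move not beyond the scatter. Compound 4 is thus estimated at 4.05, with a range from 3.6 to 4.5.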

Compound 4, partition coefficient: 3.98
Compound 4: the middle estimate sits 0.07 log units above what was measured; the measured number falls inside the stated range.
By their numbers in this assay, from the lowest: compounds 2 and 1 (each within the scatter of the next); then compounds 3 and 4 (each within the scatter of the next).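

In this assay, 3-bromo-4-methoxyphenyl in place of 4-chlorophenyl on a saturated ring carbon, next to the ring nitrogen, gives a number 0.11 log units higher from compound 3 to compound 4 (within the scatter) for this exchange of one substituted aromatic ring for another. Going by these compounds alone, this is the first reading at this position, and it shows that the number can stay within the scatter although the entering group has 9 heavy atoms and 1 hydrogen-bond acceptor, against 7 and 0 for the leaving group. No measured evidence here speaks to the reason for this outcome.

The compounds shown leave open what 3-bromophenyl and 4-methoxyphenyl would each give alone at this position, so the two substituents cannot be separated. They also leave open how an amine or a carboxylic acid on this aromatic ring would read in this assay on the shared core.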